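The compounds below may be only part of what the source reports. "The series", "measured", "known", "first", "only" and "open" are said of these compounds alone.

Measured so far in a functional assay (mast cells) for inhibition, with Rattus norvegicus as the target; on this read-out higher numbers stand for an effect only at larger amounts of compound and lower numbers for an effect already at smaller amounts:
- compound 1 `CCOC(=O)c1cnc2n(c1=O)C(C)CC/C2=N\Nc1cccc(C(=O)O)c1` gives 740000 nM
- compound 2 `CC1CC/C(=N\Nc2ccccc2)c2ncc(CC(=O)O)c(=O)n21` gives 430000 nM
- compound 3 `CC1CC/C(=N\Nc2ccccc2F)c2ncc(C(=O)O)c(=O)n21` gives 1200 nM

Compound 3 holds the lowest of the three numbers. Compound 2 is the nearer of the other two and compound 1 the further, and both gaps lie beyond the usual scatter. For the measured compounds named here, no two measured compounds differ in one place only, so the series offers no direct measure of any single change.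

The next compound is compound 4 `CC1CC/C(=N\Nc2ccc(F)cc2)c2ncc(C(=O)O)c(=O)n21` with 4-fluorophenyl in place of 2-fluorophenyl on an amine nitrogen and the rest of the structure unchanged. Going by the values given here, no measurement yet shows how much this swap matters. In this assay a modest step toward a higher number is expected, possibly no larger than the scatter. Among the compounds with values here, the expected direction rests only on compound 3 at 1200 nM being the lowest number so far, and the uncertainty is wide in both directions. The estimated move is a 2.1-fold higher number from compound 3 to compound 4 (0.32 log units; beyond the scatter). For compound 4 the expected value is 2500 nM with an estimated range from 500 nM to 15000 nM.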

Compound 4, half-maximal effective concentration: 1200 nM
For compound 4 the middle estimate is 2.1-fold (0.32 log units) above the measured one; low and high end bracket the measured number.
By their numbers in this assay, from the lowest: compounds 3 and 4 (each within the scatter of the next); then compounds 2 and 1 (each within the scatter of the next).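

In this assay, 4-fluorophenyl in place of 2-fluorophenyl on an amine nitrogen gives no change at the digits printed from compound 3 to compound 4 (within the scatter). For the compounds shown here, this is the first comparison that differs in one place only, and it shows that, with the rest of the structure unchanged, the read-out does not tell these two fluorophenyl isomers apart, so for this pair the place of the fluorine on the phenyl ring carries no measurable weight. No measurement at hand bears on why the two compounds read alike.

Open, as far as these compounds go, is whether 3-fluorophenyl, 4-chlorophenyl or 4-methoxyphenyl on the same amine nitrogen would also read alike, and whether the fluorine counts at all, a question that plain phenyl on the core of compound 3 would address. Also open, from the compounds shown here alone, is what separates compound 3 and compound 4 from compound 1 and compound 2, as those pairs differ in more than one place and no single change can be read from them.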